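Methoxystyryl Lactone and Lactam Pairs in a Growth Assay

The compounds below may be only part of what the source reports. "The series", "measured", "known", "first", "only" and "open" are said of these compounds alone.

Compound 1 `COc1ccc(/C=C/C2CC=CC(=O)O2)cc1` and compound 2 `COc1ccc(/C=C/C2CC=CC(=O)O2)cc1OC` share one core and differ only in one place: compound 2 carries methoxy in place of hydrogen on an aromatic carbon. In a functional assay on NCI-H460 cells (Homo sapiens) for inhibition, read by sulforhodamine B assay, with a stated time of 48 h (on this read-out higher numbers stand for weaker inhibition of growth and lower numbers for stronger inhibition of growth), compound 1 gives 28.3 uM. In this assay compound 2 gives 14.6 uM. The change produced a 1.9-fold lower number from compound 1 to compound 2 (0.29 log units; within the scatter), so the two values are treated as equal and no order between compound 1 and compound 2 is claimed.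

Compound 3 `COc1ccc(/C=C/C2CC=CC(=O)N2)cc1` stands on a different core; the difference between the two cores is not broken down here. In this assay compound 3 gives only a limit, > 1090 uM. This is the limit of > 1090 uM in this assay, at which 1 of the 3 values shown sits, and it is the only such limit among the three measured values.

Compound 4 `COc1ccc(/C=C/C2CC=CC(=O)N2)cc1OC` has not yet been measured in this assay. It differs from compound 3 by methoxy in place of hydrogen on an aromatic carbon, the same change as that made between compound 1 and compound 2, at the same place.

A step that the limit leaves unreadable from compound 3 to compound 4 is expected here, beside the measured 1.9-fold lower number from compound 1 to compound 2 (0.29 log units; within the scatter), because the measured step stayed within the scatter and because compound 3 reaches only the limit > 1090 uM. Compound 4 is therefore expected to give 1500 uM in this assay, most likely again reported only as a limit, with an expected range from 400 uM to 6000 uM.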

Compound 4, concentration for growth inhibition (reported as GI): > 964 uM
Compound 4 ended at the assay's limit (the forecaster's own chance of this, stated with the estimate: 85%); the middle value does not contradict the limit.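

In this assay, within the data shown here, compound 3 and compound 4 both end at limits of the assay, so no step between them can be read. For compound 3 the value is a limit: the limit of > 1090 uM in this assay, at which 1 of the 4 values shown sits. For compound 4 the value is also a limit: the limit of > 964 uM in this assay, at which 1 of the 4 values shown sits. The compounds shown leave open whether methoxy in place of hydrogen on an aromatic carbon alters growth inhibition on the core of compound 3.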